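This account rests on a few compounds, and the source may have more. Where it says the series, first, only, none or still open, it means among the compounds named here.

Measured in a functional assay on A549 cells (Homo sapiens) for antiproliferative activity, read by MTT assay, with a stated time of 72 h; a higher number here means a weaker inhibitor, a lower number a stronger inhibitor: compound 1 `C=CC(=O)Nc1cc(Nc2nc(C)cc(-c3cn(C)c4ccccc34)n2)c(OC)cc1N(C)CCN(C)C` gives 2910 nM; compound 2 `COc1cc(N(C)CCN(C)C)c(NC(=O)/C=C\C(C)C)cc1Nc1nc(C)cc(-c2cn(C)c3ccccc23)n1` gives 1070 nM; compound 3 `C=CC(=O)Nc1cc(Nc2nc(C)cc(-c3cn(C)c4ccc(F)cc34)n2)c(OC)cc1N(C)CCN(C)C` gives 1490 nM.

Compound 3 sits between the other two on these numbers; the step of a 2.0-fold lower number from compound 1 to compound 3 (0.29 log units; within the scatter) lies within the scatter, and its gap to compound 2 is likewise within the scatter. Compound 4 `COc1cc(N(C)CCN(C)C)c(NC(=O)/C=C\C(C)C)cc1Nc1nc(C)cc(-c2cn(C)c3ccc(F)cc23)n1` carries the change (3-methylbut-1-en-1-yl in place of vinyl on a carbonyl carbon). One measured step of the same kind exists, a 2.7-fold lower number from compound 1 to compound 2 (0.43 log units; beyond the scatter), a modest lowering beyond the scatter, seen on the core without the fluoro. Because a 2.7-fold lower number from compound 1 to compound 2 (0.43 log units; beyond the scatter) went that way, compound 4 is expected to give a lower number than compound 3, with the step estimated as a 2.7-fold lower number from compound 3 to compound 4 (0.43 log units; beyond the scatter). Compound 4 is therefore estimated at 550 nM, range 280 nM to 1100 nM.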

Compound 4, half-maximal inhibitory concentration: 9080 nM
For compound 4 the middle estimate is 17-fold (1.22 log units) below the measured one; the measured number lies above the stated range.
By their numbers in this assay, from the lowest: compounds 2, 3 and 1 (each within the scatter of the next, the first and the last beyond it); then compound 4.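

On the core carrying the fluoro, 3-methylbut-1-en-1-yl in place of vinyl gives a 6.1-fold higher number from compound 3 to compound 4 (0.78 log units; beyond the scatter), so this change does not keep its direction across the two cores: the same change on two cores in this assay, a 2.7-fold lower number (0.43 log units; beyond the scatter) from compound 1 to compound 2 and a 6.1-fold higher number (0.78 log units; beyond the scatter) from compound 3 to compound 4, 17-fold (1.22 log units) apart, beyond the scatter of two such steps

Fluoro in place of hydrogen, read where 3-methylbut-1-en-1-yl is present, gives an 8.5-fold higher number from compound 2 to compound 4 (0.93 log units; beyond the scatter), so it also depends on the core: the same change on two cores in this assay, a 2.0-fold lower number (0.29 log units; within the scatter) from compound 1 to compound 3 and an 8.5-fold higher number (0.93 log units; beyond the scatter) from compound 2 to compound 4, 17-fold (1.22 log units) apart, beyond the scatter of two such steps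

The two changes therefore cannot be read as independent in this series.

Going by these compounds, whether this reversal belongs to the fluoro itself or to any halogen stays open, as a chloro could show. On these data alone, it is equally open whether it needs the branched 3-methylbut-1-en-1-yl or also occurs with an unbranched propenyl chain on the carbonyl carbon.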